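The source may hold more compounds than are shown below. What is called first, only, known or untested is meant among the compounds shown, and "the series" means these compounds.

Compound 3 `C=CC(=O)Oc1c2c(cc(OC)c1C(=O)/C=C/c1ccc(OC(C)=O)cc1)OC(C)(C)CC2` carries an acryloyl ester on the core oxygen and an acetate on the phenyl oxygen. In an assay on HEK293T cells for inhibition of nuclear factor NF-kappa-B complex (Homo sapiens), read by a luciferase reporter (on this read-out higher numbers stand for weaker inhibition and lower numbers for stronger inhibition), compound 3 gives 1040 nM, the higher of the two numbers that are known here. Compound 2 `C=CC(=O)Oc1ccc(/C=C/C(=O)c2c(OC)cc3c(c2OC(=O)C=C)CCC(C)(C)O3)cc1`, which bears acryloyl esters on both oxygens, gives in this assay 290 nM. Compound 1 `COc1cc2c(c(O)c1C(=O)/C=C/c1ccc(OC(C)=O)cc1)CCC(C)(C)O2`, with a free hydroxyl on the core, gives in this assay only a limit of > 30000 nM. Two steps are on record: an at least 28-fold lower number from compound 1 to compound 3 (1.46 log units; beyond the scatter), and a 3.6-fold higher number from compound 2 to compound 3 (0.55 log units; beyond the scatter).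

Compound 4 `C=CC(=O)Oc1c2c(cc(OC)c1C(=O)/C=C/c1ccc(O)cc1)OC(C)(C)CC2` differs from compound 3 in one place: hydrogen in place of acetyl on an oxygen on an aromatic ring. Among the measured compounds shown here, no measured step removes the acyl group from the phenyl oxygen outright, but the two known steps both point the same way: taking the ester off the core oxygen, or weakening the acyl on the phenyl oxygen, raised the number. On that basis compound 4 is expected to sit somewhat weaker than compound 3, by a step of about a 1.7-fold higher number from compound 3 to compound 4 (0.24 log units; within the scatter), so compound 4 is estimated at 1800 nM in this assay, with a range from 600 nM to 6000 nM.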

Compound 4, half-maximal inhibitory concentration: 630 nM
The estimate for compound 4 lay 2.9-fold (0.46 log units) above the measured number; low and high end bracket the measured number.
By their numbers in this assay, from the lowest: compound 2; then compounds 4 and 3 (each within the scatter of the next). At a limit, above all of these: compound 1.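

In this assay the acetyl on the phenyl oxygen of compound 3 can give way to hydrogen with no change that stands clear of the scatter, the record being a 1.7-fold lower number from compound 3 to compound 4 (0.22 log units; within the scatter). An acryloyl on that same oxygen does tell, however, with a 2.2-fold higher number from compound 2 to compound 4 (0.34 log units; beyond the scatter), so at this position the identity of the acyl group matters more than the mere presence of one. Putting an acryloyl on a free hydroxyl counts for far more on the core oxygen than on the phenyl oxygen: the same change on two cores in this assay, an at least 28-fold lower number (1.46 log units; beyond the scatter) from compound 1 to compound 3 and a 2.2-fold lower number (0.34 log units; beyond the scatter) from compound 4 to compound 2, at least 13-fold (1.12 log units) apart, beyond the scatter of two such steps.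

What the compounds leave open is whether a saturated propanoyl ester on the phenyl oxygen would read like the acetyl or like the acryloyl. Also open, on these data alone, is how a methyl ether or an amine-bearing chain would fare at this oxygen.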